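The source may report more compounds than this note shows. Statements on the series, on what has been measured and on what is new or still open speak of the compounds shown alone.

Measured so far in an ADME assay on the whole organism with Oryza sativa as the target, tested at 0.1 uM; a lower number here means a stronger effect, a higher number a weaker effect of the compound at the concentration tested:
compound 1 `Cc1cccc(NC(=O)N[C@@H](C)c2ccccc2)c1`: 99%
compound 2 `CCc1cccc(NC(=O)N[C@@H](C)c2ccccc2)c1`: 100%
compound 3 `CC(C)c1cccc(NC(=O)N[C@H](C)c2ccccc2)c1`: 74%

Compound 3 stands lowest of the three numbers, beyond the scatter from both compound 1 and compound 2. Among the measured compounds shown here, the single measured step, a number 1 percentage points higher from compound 1 to compound 2 (within the scatter), concerns a change on the saturated chain and says nothing about configuration, so no measured step bears directly on the next change.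

Compound 4 `CC(C)c1cccc(NC(=O)N[C@@H](C)c2ccccc2)c1` differs from compound 3 by the two compounds have the same atoms and bonds and differ only in configuration as drawn: 1 of 1 stereo elements differ; a stereocentre at a saturated chain carbon is drawn R in compound 3 and S in compound 4. For the measured compounds named here, compound 1 and compound 2 carry the same drawn configuration as compound 4 and both give numbers near the top of the scale, while the only compound drawn the other way, compound 3, sits lower; this is suggestive only, since the chain group also changes between those pairs. A step upward in this assay is therefore expected, with wide uncertainty. Compound 4 is estimated at 87% (range 62% to 100%), an expected step of a number 13 percentage points higher from compound 3 to compound 4 (beyond the scatter).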

Compound 4, a percentage reported as activity, at one concentration (the size of the read-out at that concentration, not a potency): 95%
Beside the measured number, compound 4's estimate is 8 percentage points below it, within the range that was stated.
By their numbers in this assay, from the lowest: compound 3; then compounds 4, 1 and 2 (each within the scatter of the next).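

In this assay the drawn configuration at the saturated chain carbon matters on its own, with a number 21 percentage points higher from compound 3 to compound 4 (beyond the scatter), and the step can be assigned to that stereocentre because of one fact: the fact that compounds 3 and 4 differ only in the configuration as drawn

With the S drawing held, the alkyl group on the aromatic carbon makes no difference beyond the scatter: isopropyl in place of methyl gives a number 4 percentage points lower from compound 1 to compound 4 (within the scatter), and the change from ethyl to isopropyl gives a number 5 percentage points lower from compound 2 to compound 4 (within the scatter).

The compounds shown leave open whether the R drawing lowers the number when methyl or ethyl takes the place of isopropyl, and what a methoxy group or a carboxylic acid there would do.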